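This account rests on a few compounds, and the source may have more. Where it says the series, first, only, none or still open, it means among the compounds named here.

The study concerns a small set of sulfones tested in a functional assay on MCF7 cells (Homo sapiens) for cytotoxicity, read by MTT assay, with a stated time of 72 h; a lower number here means a stronger inhibitor of growth, a higher number a weaker inhibitor of growth. Compound 1, with the structure `COc1cc(OC)c(/C=C/S(=O)(=O)Cc2ccc(OC)c(N)c2)c(OC)c1`, gives in this assay a value that is a limit of the assay, < 10 nM, as noted in the limit of < 10 nM in this assay, at which 1 of the 3 values shown sits. Compound 3, with the structure `COc1ccc(CS(=O)(=O)/C=C/c2ccc(OC)c(OC)c2OC)cc1N`, gives in this assay a value of 5950 nM. Compound 2, with the structure `COc1ccc(CS(=O)(=O)CC(=O)Nc2c(C)cc(C)cc2C)cc1[N+](=O)[O-]`, stands apart from both: in this assay compound 2 gives only a limit of the assay, > 30000 nM, which is the upper limit named in the limit of > 30000 nM in this assay, at which 1 of the 3 values shown sits, so no number is known for it, only that it lies at the weak end of the shown results.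

The step under consideration goes from compound 2 to compound 4, with the structure `COc1ccc(CS(=O)(=O)CC(=O)Nc2c(C)cc(C)cc2C)cc1N`. The change is amino in place of nitro on an aromatic carbon, ortho to a methoxy group and meta to a large group. Among the measured compounds shown here, no measured pair shows this same change on this scaffold, so no size of step can be read off; the account expects no step in this assay beyond the usual scatter, with the result for compound 4 most likely again near the limit. On that basis compound 4 is estimated to give in this assay about 30000 nM, between 8000 nM and 100000 nM, a step of a number no higher from compound 2 to compound 4 (the limit leaves the size open) that is expected rather than measured.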

Compound 4, concentration for 50% growth inhibition: > 30000 nM
Compound 4 gave a limit, no number; the forecaster's own chance of this, stated with the estimate: 55%; the middle value sits exactly at the limit.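

In this assay compound 4 gives > 30000 nM, a limit of the assay and not a number. Compound 2 also sits at this limit, so no step can be read between compound 2 and compound 4: the limit of > 30000 nM in this assay, at which 2 of the 4 values shown sit. The compounds shown leave open whether amino in place of nitro on an aromatic carbon alters growth inhibition on this shared core.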